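Swapping a fluorine for bromine on the amide phenyl

The source may hold more compounds than are shown below. What is called first, only, known or untested is meant among the compounds shown, and "the series" means these compounds.

Three compounds share one core and differ only in the aromatic group attached to the carbonyl carbon of an amide. In a functional assay on MCF7 cells (Homo sapiens) for inhibition, read by MTT assay (a higher number here means a weaker inhibitor, a lower number a stronger inhibitor), compound 1 `COc1cc2ncnc(Nc3ccc(NC(=O)c4ccc(C(C)(C)C)cc4)cc3)c2cc1OC` gives > 100000 nM, which is a limit of the assay rather than a number. Compound 2 `COc1cc2ncnc(Nc3ccc(NC(=O)c4ccccc4F)cc3)c2cc1OC` gives 11000 nM in this assay, and compound 3 `COc1cc2ncnc(Nc3ccc(NC(=O)c4cccc(F)c4)cc3)c2cc1OC` gives 13600 nM. Among the two numbers shown, compound 2 stands lowest, with compound 3 within the usual scatter of it, as a 1.2-fold higher number from compound 2 to compound 3 (0.09 log units; within the scatter) shows, so neither can be called the stronger one. The two measured steps away from the bulky 4-(tert-butyl)phenyl were an at least 9.0-fold lower number from compound 1 to compound 2 (0.95 log units; beyond the scatter) and an at least 7.3-fold lower number from compound 1 to compound 3 (0.86 log units; beyond the scatter). Compound 4 `COc1cc2ncnc(Nc3ccc(NC(=O)c4ccc(Br)cc4)cc3)c2cc1OC` has not been measured. The change from compound 2 is 4-bromophenyl in place of 2-fluorophenyl on a carbonyl carbon. Going by the values given here, no measured step involves a 4-bromophenyl, so the step can only be read as lying between the small fluorine groups and the large 4-(tert-butyl)phenyl. A higher number for compound 4 than for compound 2 is therefore expected, of about a 2.7-fold higher number from compound 2 to compound 4 (0.44 log units; beyond the scatter), with a real chance that this assay again reports only a limit. The expected value for compound 4 is 30000 nM, with a range from 8000 nM to 100000 nM.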

Compound 4, half-maximal inhibitory concentration: 43000 nM
Estimate against measurement, compound 4: 1.4-fold (0.16 log units) below; measured number inside the range.
By their numbers in this assay, from the lowest: compounds 2 and 3 (each within the scatter of the next); then compound 4. At a limit, above all of these: compound 1.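

In this assay, going by these compounds alone, 4-bromophenyl is the first group on this carbonyl carbon to give a measured number clearly separated from the two fluorophenyl compounds, with a 3.9-fold higher number from compound 2 to compound 4 (0.59 log units; beyond the scatter) and a 3.2-fold higher number from compound 3 to compound 4 (0.50 log units; beyond the scatter). On the other side, the change from 4-(tert-butyl)phenyl to 4-bromophenyl gives an at least 2.3-fold lower number from compound 1 to compound 4 (0.36 log units; beyond the scatter), so the order at this position now has three distinct levels: the two fluorophenyl compounds, then compound 4, then compound 1. Compound 1 stands at a limit and has no exact number, so this last step gives only a minimum size: the limit of > 100000 nM in this assay, at which 1 of the 4 values shown sits.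

Compound 4 differs from compound 2 and compound 3 in both the halogen and its place on the ring, and the compounds shown cannot separate these two changes; a 4-fluorophenyl or a 2-bromophenyl would be needed to do so. Also open, from the compounds shown here alone, is how a group of a different kind, such as a 4-aminophenyl or a 4-methoxyphenyl, would read on this carbonyl carbon.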